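The source may report more compounds than this note shows. Statements on the series, on what has been measured and on what is new or still open speak of the compounds shown alone.

Compound 2 `Cc1ccccc1Nc1nc(C)c(C(=O)/C=C/c2ccccc2)s1` has been tested in a functional assay on BGC-823 cells (Homo sapiens) for cytotoxicity, read by MTT assay; on this read-out higher numbers stand for weaker inhibition and lower numbers for stronger inhibition. In that test compound 2 reaches only the limit of > 25000 nM, which is a bound of the measurement and not a number. Compound 1 `Cc1nc(Nc2ccc(Cl)c(Cl)c2)sc1C(=O)/C=C/c1ccccc1` gives 10600 nM in this assay. Going by the values given here, the single measured step, an at least 2.3-fold higher number from compound 1 to compound 2 (0.37 log units; beyond the scatter), is known only as a lower bound, given (the limit of > 25000 nM in this assay, at which 1 of the 2 values shown sits). Compound 3 `Cc1nc(Nc2ccccc2)sc1C(=O)/C=C/c1ccccc1` differs from compound 2 by hydrogen in place of methyl on an aromatic carbon. Among the compounds with values here, no measured step matches this change; the step from compound 1 to compound 2 exchanges the whole aryl substituent and says nothing about removing the methyl on its own. The step of an at least 1.1-fold lower number from compound 2 to compound 3 (0.05 log units; that floor lies within the scatter) is therefore expected to be small or within the scatter, with a real chance that compound 3 again sits at the limit. Compound 3 is estimated at 22000 nM, within a range from 8000 nM to 60000 nM.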

Compound 3, half-maximal inhibitory concentration: 19500 nM
Compound 3: the middle estimate sits 1.1-fold (0.05 log units) above what was measured; measured number inside the range.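

In this assay, the anilino group of compound 3 gives this series a measured reference without any substituent on the phenyl ring. The step of a 1.8-fold higher number from compound 1 to compound 3 (0.26 log units; within the scatter) shows that the 3,4-dichlorophenyl group cannot be told apart from phenyl here, which the earlier comparison between compounds could not show. The step of an at least 1.2-fold lower number from compound 2 to compound 3 (0.10 log units; that floor lies within the scatter) gives only a floor within the scatter, so the effect of the 2-methyl group stays unsized, and the entry for compound 2 is a limit and not a number: the limit of > 25000 nM in this assay, at which 1 of the 3 values shown sits.

From the compounds shown here alone, it remains open whether a single chlorine, a methoxy group, an amine or a carboxylic acid on this phenyl ring would move the number beyond the scatter. Going by these compounds, it is also open how far the other phenyl ring, on the far side of the carbonyl, matters.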